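The compounds below may be only part of what the source reports. "The series", "measured", "known", "first", "only" and "open" are said of these compounds alone.

Among the compounds with values here, compound 2 `CC(C)(C)OC(=O)N1CCC(c2coc3c(N4CCc5cc(S(C)(=O)=O)ccc54)ncnc23)CC1` gives 123% in a functional assay on cells for agonist activity at Glucose-dependent insulinotropic receptor (Homo sapiens), read by a luciferase reporter, with a stated time of 4 h (a lower number here means a smaller maximal response, a higher number a larger maximal response), the highest of the two numbers in hand; compound 1 `CC(C)(C)OC(=O)N1CCC(c2c[nH]c3c(Nc4ccc(S(C)(=O)=O)cc4F)ncnc23)CC1` gives 9% in this assay, a gap beyond the scatter, though the two differ in more than one place and no single step links them. Compound 3 `CCc1cnc(N2CCC(c3coc4c(N5CCc6cc(S(C)(=O)=O)ccc65)ncnc34)CC2)nc1` differs from compound 2 by 5-ethylpyrimidin-2-yl in place of tert-butoxycarbonyl on an amine nitrogen in a ring. Within the data shown here, no measured pair isolates this change, so the expected step of a number 13 percentage points lower from compound 2 to compound 3 (beyond the scatter) is a modest loss, likely within the scatter, with a wide margin of uncertainty. Compound 3 is expected to reach 110% in this assay, plausibly between 60% and 140%.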

Compound 3, largest response reached (Emax), in percent of the reference or control that the assay uses: 154%
Compound 3: the middle estimate sits 44 percentage points below what was measured, and the stated range ends below it.
By their numbers in this assay, from the lowest: compound 1; then compound 2; then compound 3.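

On the amine nitrogen of the six-membered non-aromatic ring, 5-ethylpyrimidin-2-yl in place of tert-butoxycarbonyl gives a number 31 percentage points higher from compound 2 to compound 3 (beyond the scatter) in this assay and is a large step. The maximal response of this series is therefore not tied to tert-butoxycarbonyl at this position, since an aromatic ring with two hetero atoms serves there too. Nothing at hand explains the gain.

On these data alone, whether the ethyl group contributes remains open, as does how a pyrimidin-2-yl without it, or a 5-methyl or 5-chloro analogue, would behave. Also open, as far as these compounds go, is whether the step carries over to the core of compound 1.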